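A few compounds are considered here, and "the series" means these few. Any claim that something is new, unique, unknown or untested is made for them only; others in the source may bear on it.

Compound 1, `CCSc1ccc(C2C(O)C(=O)N2c2cc(OC)c(OC)c(OC)c2)cc1`, in a functional assay on HT-29 cells (Homo sapiens) for inhibition, read by sulforhodamine B assay, with a stated time of 72 h (a lower number here means a stronger inhibitor, a higher number a weaker inhibitor), gives 12 nM.
Compound 2, `CCSc1ccc(C2CC(=O)N2c2cc(OC)c(OC)c(OC)c2)cc1`, gives 311 nM.
Compound 3, `COc1ccc(C2CC(=O)N2c2cc(OC)c(OC)c(OC)c2)cc1`, gives 65 nM.

Compound 2 stands highest of the three numbers in this assay: the nearest number is that of compound 3, a 4.8-fold lower number from compound 2 to compound 3 (0.68 log units; beyond the scatter), and the furthest is that of compound 1, a 26-fold higher number from compound 1 to compound 2 (1.41 log units; beyond the scatter). Compound 4, `CCSc1ccc(C2C(C3CC3)C(=O)N2c2cc(OC)c(OC)c(OC)c2)cc1`, differs from compound 2 in one place: cyclopropyl in place of hydrogen on a saturated ring carbon. Going by the values given here, the measured step that bears on this is the one from compound 1 to compound 2, a 26-fold higher number from compound 1 to compound 2 (1.41 log units; beyond the scatter), a large change at the same saturated ring carbon, though with hydroxy rather than cyclopropyl; no measured step involves cyclopropyl. A lower number beyond the scatter is therefore expected, but a modest one. Compound 4 is estimated at 100 nM, within 20 nM to 500 nM, an expected step of a 3.1-fold lower number from compound 2 to compound 4 (0.49 log units; beyond the scatter).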

Compound 4, half-maximal inhibitory concentration: 1560 nM
Beside the measured number, compound 4's estimate is 16-fold (1.19 log units) below it, and the stated range ends below it.
By their numbers in this assay, from the lowest: compound 1; then compound 3; then compound 2; then compound 4.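

Putting a group on this saturated ring carbon does not by itself give a stronger inhibitor: cyclopropyl brings a 5.0-fold higher number from compound 2 to compound 4 (0.70 log units; beyond the scatter) and so moves the number the opposite way from hydroxy. Measured directly against hydroxy on the same carbon, cyclopropyl gives a 130-fold higher number from compound 1 to compound 4 (2.11 log units; beyond the scatter) and so shows how much depends on which group sits there. Nothing measured here explains this difference. Going by these compounds, whether an amine or a methyl group on this carbon would behave more like hydroxy or like cyclopropyl remains open, as does whether cyclopropyl would have the same effect with methoxy in place of ethylsulfanyl.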